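A few compounds are considered here, and "the series" means these few. Any claim that something is new, unique, unknown or untested is made for them only; others in the source may bear on it.

Measured so far in a functional assay on KETR3 cells (Homo sapiens) for inhibition, read by MTT assay, with a stated time of 120 h; a lower number here means a stronger inhibitor, a higher number a weaker inhibitor:
compound 2 `CC(NC(=O)C#Cc1ccc(NC(=O)Nc2cc(C(F)(F)F)ccc2Cl)cc1)c1ccccc1`: 23200 nM
compound 3 `CNC(=O)/C=C/c1ccc(NC(=O)Nc2ccc(Cl)c(C(F)(F)F)c2)cc1`: 21200 nM
compound 1 `C/C(=C\c1ccc(NC(=O)Nc2ccc(Cl)c(C(F)(F)F)c2)cc1)C(=O)NC(C)c1ccccc1`: > 50000 nM

For compound 1 this value is a limit of this assay and not a number (the limit of > 50000 nM in this assay, at which 1 of the 3 values shown sits). Among the compounds with values here, compound 2 and compound 3 give the only two numbers, and they lie within the usual scatter of each other. Compound 4 `CC(NC(=O)C#Cc1ccc(NC(=O)Nc2ccc(Cl)c(C(F)(F)F)c2)cc1)c1ccccc1` is not yet measured in this assay. It has the same atoms as compound 2, joined differently: 4-chloro-3-(trifluoromethyl)phenyl in place of 2-chloro-5-(trifluoromethyl)phenyl on an amide-type nitrogen. Within the data shown here, no measured pair reports this change on its own. Compound 3 carries the entering 4-chloro-3-(trifluoromethyl)phenyl and gives 21200 nM, so no step beyond the scatter is expected from compound 2 to compound 4, a 1.1-fold lower number from compound 2 to compound 4 (0.02 log units; within the scatter). Compound 4 is estimated at 22000 nM, in a range from 8000 nM to 60000 nM.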

Compound 4, half-maximal inhibitory concentration: 21400 nM
Compound 4: the middle estimate sits 1.0-fold (0.01 log units) above what was measured, within the range that was stated.
By their numbers in this assay, from the lowest: compounds 3, 4 and 2 (each within the scatter of the next). At a limit, above all of these: compound 1.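

In this assay, within the data shown here, the pair compound 2 and compound 4 isolates the exchange of 2-chloro-5-(trifluoromethyl)phenyl for 4-chloro-3-(trifluoromethyl)phenyl on an amide-type nitrogen, which the earlier compounds could not do. The result is a 1.1-fold lower number from compound 2 to compound 4 (0.04 log units; within the scatter), so at this position, with the core of compound 2, the two arrangements are not told apart. No available measurement bears on this step.

Open, going by these compounds, is whether a phenyl bearing an amine or a carboxylic acid at this nitrogen would shift the value. Also open, on these data alone, is whether the same exchange reads alike on the cores of compound 1 and compound 3.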